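The source may hold more compounds than are shown below. What is called first, only, known or untested is meant among the compounds shown, and "the series" means these compounds.

Measured so far:
compound 1 `Cc1ccc(C(=O)OC2(C(=O)Nc3ccc([N+](=O)[O-])cc3)CCCCC2)cc1` — 45.4 nM
compound 2 `CC(=O)OC1(C(=O)Nc2ccc([N+](=O)[O-])cc2)CCCCC1` — 517 nM

Compound 1 stands lowest of the two numbers in a functional assay on NFS-60 cells (Mus musculus) for inhibition, read by MTT assay, with a stated time of 72 h; a higher number here means a weaker inhibitor, a lower number a stronger inhibitor; its nearest neighbour is compound 2, separated by an 11-fold higher number from compound 1 to compound 2 (1.06 log units; beyond the scatter). The next compound, compound 3 `CC(=O)Oc1ccccc1C(=O)OC1(C(=O)Nc2ccc([N+](=O)[O-])cc2)CCCCC1`, differs from compound 1 in one place: 2-acetoxyphenyl in place of 4-methylphenyl on a carbonyl carbon. Going by the values given here, the only measured step, an 11-fold higher number from compound 1 to compound 2 (1.06 log units; beyond the scatter), sits on the same carbonyl carbon, and there the loss of the whole aromatic ring gave a large rise in the number. Among the compounds with values here, compound 3 keeps an aromatic ring at that carbonyl carbon, so that step bears on it only loosely; no measured pair compares 2-acetoxyphenyl with 4-methylphenyl. A small shift, if any, is expected, leaning toward a slightly higher number. The estimate for compound 3 is 70 nM, expected to fall between 25 nM and 200 nM. The expected step is therefore a 1.5-fold higher number from compound 1 to compound 3 (0.19 log units; within the scatter).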

Compound 3, half-maximal inhibitory concentration: 11.3 nM
Compound 3: the middle estimate sits 6.2-fold (0.79 log units) above what was measured; measured number below the stated range.
By their numbers in this assay, from the lowest: compound 3; then compound 1; then compound 2.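

In this assay, going by these compounds alone, the earlier compounds showed only that losing the aromatic ring at this carbonyl carbon raised the number, whereas the exchange of 4-methylphenyl for 2-acetoxyphenyl gave a 4.0-fold lower number from compound 1 to compound 3 (0.60 log units; beyond the scatter) while an aromatic ring stayed in place. The identity of the aromatic group here therefore matters as well as its presence, and 2-acetoxyphenyl in place of methyl gave a 46-fold lower number from compound 2 to compound 3 (1.66 log units; beyond the scatter) at this same place. Nothing available accounts for the lower number of compound 3.

The compounds shown do not separate the contribution of the acetoxy group from that of the ring itself, since neither an unsubstituted phenyl nor a ring carrying a hydroxyl in place of the acetoxy group appears among them. From the compounds shown here alone, whether an amine or a carboxylic acid on that ring would keep the low number also remains open.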